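A few compounds are considered here, and "the series" means these few. Any claim that something is new, unique, unknown or untested is made for them only; others in the source may bear on it.

Measured compounds:
Compound 1, `Cc1ccc(Nc2ncc3c(n2)N(C)C(=O)N(c2cc(NC(=O)c4cccc(C(F)(F)F)c4)ccc2C)C3)cc1`, gives 8000 nM in an ADME assay on BaF3 cells (Mus musculus) for antiproliferative activity, read by CellTiter-Glo and CCK-8 assay, with a stated time of 72 h; on this read-out lower numbers stand for stronger inhibition of growth and higher numbers for weaker inhibition of growth.
Compound 2, `Cc1cc(C)cc(C(=O)Nc2ccc(C)c(N3Cc4cnc(Nc5ccc(C)c(N)c5)nc4N(C)C3=O)c2)c1`, gives only a limit of the assay in this assay, namely > 10000 nM.

Going by the values given here, compound 1 therefore holds the only actual number among the two results, the other entry being a limit (the limit of > 10000 nM in this assay, at which 1 of the 2 values shown sits). Compound 3, `Cc1ccc(NC(=O)c2cccc(C(F)(F)F)c2)cc1N1Cc2cnc(O[C@H]3CCNC3)nc2N(C)C1=O`, has not yet been tested. It differs from compound 1 in one place: (pyrrolidin-3-yl)oxy in place of (4-methylphenyl)amino on an aromatic carbon. Among the compounds with values here, no step between two measured compounds shows what such an exchange does here, so the expectation rests on compound 1 alone. Since compound 1 already sits at a weak 8000 nM and the exchange replaces a sizeable group, a shift in either direction beyond the usual scatter cannot be excluded. The expected step in this assay is a 1.1-fold higher number from compound 1 to compound 3 (0.05 log units; within the scatter), toward weaker growth inhibition, with a real chance that only a limit is reported. Compound 3 is estimated at 9000 nM, between 2500 nM and 30000 nM.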

Compound 3, concentration for 50% growth inhibition: > 10000 nM
Compound 3: no number, only a limit (the forecaster's own chance of this, stated with the estimate: 45%); middle value at least 1.1-fold (0.04 log units) from the limit.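

In this assay compound 3 gives only a limit of the assay, > 10000 nM, and not a number. The exchange of (4-methylphenyl)amino for (pyrrolidin-3-yl)oxy at this position, between two ring nitrogen atoms, is therefore known only as an at least 1.2-fold higher number from compound 1 to compound 3 (0.09 log units; that floor lies within the scatter), so a real change cannot be told from none at all. What is new is that this non-aromatic ring joined through oxygen yields no measurable growth inhibition here, and the series now leans heavily on that ceiling: the limit of > 10000 nM in this assay, at which 2 of the 3 values shown sit.

Going by these compounds, how far compound 3 truly lies from compound 1 stays open, since a limit gives no size. Also open, on these data alone, is what other groups at this position would do, such as a morpholine, a simple alkylamine or a pyridinylamino group.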